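Compound 4 and a series held at the assay limit

The source may hold more compounds than are shown below. What is called first, only, known or untested is meant among the compounds shown, and "the series" means these compounds.

Measured so far in an ADME assay on RAW264.7 cells (Mus musculus) for cytotoxicity, read by MTT assay, with a stated time of 24 h, in the absence of a further agent (on this read-out higher numbers stand for weaker inhibition and lower numbers for stronger inhibition), each value a limit of the assay and not a number:
Compound 1 `CCCCCCOc1ccc(C(O)C2OC(=O)c3c(OC)cc(OC)cc32)cc1` gives > 40000 nM as a limit
Compound 2 `CCC(C)Oc1ccc(C(O)C2OC(=O)c3c(OC)cc(OC)cc32)cc1` gives > 40000 nM as a limit
Compound 3 `COCCOc1ccc(C(O)C2OC(=O)c3c(OC)cc(OC)cc32)cc1` gives > 40000 nM as a limit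

Compound 3 reports > 40000 nM as a limit, so it cannot be ranked against the other two. The whole set rests on the limit of > 40000 nM in this assay, at which 3 of the 3 values shown sit, and on nothing finer. Compound 4 `COCCCCOc1ccc(C(O)C2OC(=O)c3c(OC)cc(OC)cc32)cc1` differs from compound 3 by one change 2-methoxyethyl in place of methoxy on a saturated chain carbon, two bonds along the chain from an oxygen on an aromatic ring in which 2-methoxyethyl takes the place of methoxy on a saturated chain carbon, two bonds along the chain from an oxygen on an aromatic ring.

The nearest measured change at that place is a step that the two limits leave unreadable from compound 1 to compound 3 with methoxy in place of butyl. Two more steps bear on it, namely a step that the two limits leave unreadable from compound 1 to compound 2 and a step that the two limits leave unreadable from compound 2 to compound 3 with the group on the oxygen changed. None of the three has a readable size or direction, so no step beyond the scatter is expected in this assay for the longer chain. The expected step is a step that the limit leaves unreadable from compound 3 to compound 4 as an estimate only. For compound 4 the estimate is 50000 nM with an expected range from 30000 nM to 100000 nM and a further limit is the most likely report.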

Compound 4, half-maximal inhibitory concentration: > 40000 nM
Compound 4: only a limit was reported; the forecaster's own chance of this, stated with the estimate: 90%; the middle value lies beyond the limit too.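

In this assay compound 4 gives > 40000 nM as a limit of the assay and not a number. No step can be read between compound 4 and compound 1, compound 2 or compound 3, because all four rest on the same limit: the limit of > 40000 nM in this assay, at which 4 of the 4 values shown sit.

The compounds shown leave open how far beyond that limit each one lies and whether the group on the oxygen changes this read-out at all.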